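From 3-methoxyphenyl to thiophen-3-yl: a small step expected

The source may report more compounds than this note shows. Statements on the series, on what has been measured and on what is new or still open speak of the compounds shown alone.

In a functional assay on SK-OV-3 cells (Homo sapiens) for cytotoxicity (a higher number here means a weaker inhibitor, a lower number a stronger inhibitor), compound 1 (`C=C/C=C\[C@H](C)[C@H](OC(N)=O)[C@@H](C)[C@H](O)[C@@H](C)C/C(C)=C\[C@H](C)[C@@H](O)[C@@H](C)/C=C\CCc1cc(F)cc(F)c1`) gives 360 nM and compound 2 (`C=C/C=C\[C@H](C)[C@H](OC(N)=O)[C@@H](C)[C@H](O)[C@@H](C)C/C(C)=C\[C@H](C)[C@@H](O)[C@@H](C)/C=C\CCc1cccc(OC)c1`) gives 370 nM so compound 2 stands level with compound 1 within the scatter. Compound 3 (`C=C/C=C\[C@H](C)[C@H](OC(N)=O)[C@@H](C)[C@H](O)[C@@H](C)C/C(C)=C\[C@H](C)[C@@H](O)[C@@H](C)/C=C\CCc1ccsc1`) is still unmeasured. The change from compound 2 (thiophen-3-yl in place of 3-methoxyphenyl on a saturated chain carbon, two bonds along the chain from a double-bonded chain carbon) puts thiophen-3-yl in place of 3-methoxyphenyl on a saturated chain carbon, two bonds along the chain from a double-bonded chain carbon. Among the measured compounds shown here, one measured step bears on this, at the same place: 3-methoxyphenyl in place of 3,5-difluorophenyl left the two values within the scatter (a 1.0-fold higher number from compound 1 to compound 2 (0.01 log units; within the scatter)). That step joins two phenyl groups, and no five-membered ring has been measured here, so the evidence is thin. No step beyond the scatter is therefore expected in this assay in either direction, and the estimated step is small (a 1.1-fold higher number from compound 2 to compound 3 (0.03 log units; within the scatter)). Compound 3 is estimated at 400 nM (expected range 170 nM to 950 nM).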

Compound 3, half-maximal inhibitory concentration: 440 nM
For compound 3 the middle estimate is 1.1-fold (0.04 log units) below the measured one; low and high end bracket the measured number.
By their numbers in this assay, from the lowest: compounds 1, 2 and 3 (each within the scatter of the next).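

Among the compounds shown here, at this position, on a saturated chain carbon, two bonds along the chain from a double-bonded chain carbon, the earlier compounds carried only phenyl groups; compound 3 shows that a five-membered aromatic ring with a sulfur atom also stays within the scatter in this assay. The steps read a 1.2-fold higher number from compound 2 to compound 3 (0.08 log units; within the scatter) and a 1.2-fold higher number from compound 1 to compound 3 (0.09 log units; within the scatter), so 3,5-difluorophenyl, 3-methoxyphenyl and thiophen-3-yl cannot be told apart in this read-out. Nothing in the data accounts for this level result.

From the compounds shown here alone, all three compounds end in an aromatic ring, so what an amine, a carboxylic acid or a longer chain would do in that place stays open. Also open, going by these compounds, is whether thiophen-2-yl would read like thiophen-3-yl.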